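The source may report more compounds than this note shows. Statements on the series, on what has been measured and on what is new or still open speak of the compounds shown alone.

Among the measured compounds shown here, in an ADME assay on microsomes from liver (Rattus norvegicus) for metabolic stability, using NADPH, with a stated time of 10 min (a higher number here means that more of the compound is left, a lower number that less of the compound is left), compound 1 `NCCCCN(C[C@H]1Cc2ncccc2CN1)[C@H]1CCCc2cccnc21` gives 64%, the top end of the numbers so far, shared with its close relative. That relative, compound 2 `NCCCCN(C[C@@H]1Cc2ncccc2CN1)[C@H]1CCCc2cccnc21`, differs only in configuration as drawn and gives 55%. The comparison shows a number 9 percentage points lower from compound 1 to compound 2 (within the scatter), so this assay does not separate the pair. Compound 3 `NC(=O)NC/C=C\CN(C[C@H]1Cc2ncccc2CN1)[C@H]1CCCc2cccnc21` has a longer group on the amine nitrogen and gives 1%.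

Compound 4 `CN(CCCCN(C[C@H]1Cc2ncccc2CN1)[C@H]1CCCc2cccnc21)C1CCC(F)(F)CC1` keeps the core of compound 1, including its configuration, and changes only the end of the chain: a group of 10 heavy atoms (7 carbon, 1 nitrogen, 2 fluorine; one six-membered non-aromatic ring of carbon only) in place of one nitrogen atom, on a saturated chain carbon, four bonds along the chain from an amine nitrogen. The configuration step therefore offers little guidance here. The closer precedent is compound 3, where changing the same side of the molecule gave a number 63 percentage points lower from compound 1 to compound 3 (beyond the scatter). That single precedent involves a different group, so it supports the direction of the change better than its size. The expected change is a number 44 percentage points lower from compound 1 to compound 4 (beyond the scatter), a fall beyond the scatter but with wide uncertainty. For compound 4, the estimated value is 20%, with an expected range of 5% to 45%.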

Compound 4, percent of the compound remaining: 8%
Estimate against measurement, compound 4: 12 percentage points above, and the stated range covers the measured number.
By their numbers in this assay, from the lowest: compounds 3 and 4 (each within the scatter of the next); then compounds 2 and 1 (each within the scatter of the next).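

In this assay, the new result isolates the end of the chain: compound 4 keeps the core, its configuration and the chain of compound 1, and replaces only the amino group, on a saturated chain carbon, four bonds along the chain from an amine nitrogen. The outcome is a number 56 percentage points lower from compound 1 to compound 4 (beyond the scatter), so a change at this position alone is enough to produce a large fall, whereas compound 3 also differs from compound 1 in the chain itself. Nothing given here explains why this replacement has such an effect.

Going by these compounds, it remains open whether a simple dimethylamino group at the same place would give a similar number, or whether the six-membered ring or its two fluorine atoms matter. A hydroxyl group or a carboxylic acid at the chain end would also test how this position responds to a group without an amine nitrogen.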